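The source may report more compounds than this note shows. Statements on the series, on what has been measured and on what is new or still open speak of the compounds shown alone.

Compound 3, with the structure `CC(O)n1cnc2c(S)nc(F)nc21`, is one of three compounds of a shared core tested in a functional assay on WI-38 cells (Homo sapiens) for inhibition; on this read-out lower numbers stand for stronger inhibition and higher numbers for weaker inhibition. In this assay compound 3 gives only a limit of > 500000 nM, not a number. Compound 1, with the structure `CC(=O)OC(C)n1cnc2c(S)nc(F)nc21`, likewise gives only a limit of > 500000 nM in this assay. Compound 2, with the structure `CC(=O)OCCOn1cnc2c(S)nc(F)nc21`, also gives only a limit of > 500000 nM in this assay. For the measured compounds named here, the one step between measured compounds, hydrogen in place of acetyl on an oxygen on a saturated carbon, runs a step that the two limits leave unreadable from compound 1 to compound 3 and cannot be read, since both ends are limits; the reason is the limit of > 500000 nM in this assay, at which 3 of the 3 values shown sit, where every value shown sits. Compound 3 therefore stands at the same limit as the other two, with no measured order among them.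

Compound 4, with the structure `OCCOn1cnc2c(S)nc(F)nc21`, differs from compound 3 by 2-hydroxyethoxy in place of 1-hydroxyethyl on an aromatic nitrogen. Going by the values given here, no measured step touches this change, and the single step between measured compounds gives no size. From the shared limit the expectation for compound 4 is another limit or a weak number. The step from compound 3 to compound 4 in this assay is expected to be about a step that the limit leaves unreadable from compound 3 to compound 4, which is not readable against a limit. Compound 4 is estimated in this assay at 600000 nM, between 200000 nM and 2000000 nM.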

Compound 4, half-maximal inhibitory concentration: > 500000 nM
Compound 4 gave a limit, no number (the forecaster's own chance of this, stated with the estimate: 85%); the middle value does not contradict the limit.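

No new step can be read from compound 3 to compound 4 or from compound 2 to compound 4, since both ends of each pair are limits and not numbers: the limit of > 500000 nM in this assay, at which 4 of the 4 values shown sit. The compounds shown leave open how these four compounds rank against one another, and whether any change to the shared core gives a number in this assay at all.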